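A few compounds are considered here, and "the series" means these few. Any claim that something is new, unique, unknown or untested is made for them only; others in the source may bear on it.

Measured in a functional assay on A549 cells (Homo sapiens) for cytotoxicity, read by MTT assay, with a stated time of 24 h; a higher number here means a weaker inhibitor, a lower number a stronger inhibitor:
Compound 1 `O=c1nc2ccccn2cc1Cc1ccc(F)cc1C(F)(F)F`: > 1000000 nM
Compound 2 `CC1(C)OC2O[C@@H](Cc3cn4ccccc4nc3=O)C(OCc3ccccc3)C2O1`: 199000 nM
Compound 3 `Nc1cc(Br)cn2cc(Cc3ccccc3)c(=O)nc12`: > 1000000 nM

The entry for compound 1 is a limit of the assay and not a number. The entry for compound 3 is likewise only a limit. Together they mark (the limit of > 1000000 nM in this assay, at which 2 of the 3 values shown sit).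

Within the data shown here, compound 2, at 199000 nM, carries the only true number in the set, so it is the sole quantitative reference point. Compound 4 `CC1(C)OC2O[C@@H](Cc3cn4cc(Cl)ccc4nc3=O)C(OCc3ccccc3)C2O1` keeps the frame of compound 2 and changes one position: chloro in place of hydrogen on an aromatic carbon. This is chloro in place of hydrogen on an aromatic carbon, on the six-membered aromatic ring with 1 nitrogen, two atoms from the ring nitrogen.

Among the measured compounds shown here, no measured pair shows this change, so the expectation rests on compound 2 alone, at 199000 nM. A small step is expected, a 1.3-fold lower number from compound 2 to compound 4 (0.12 log units; within the scatter) in this assay, toward a stronger inhibitor and close to the scatter. For compound 4 the estimated value is 150000 nM, with an expected range of 60000 nM to 400000 nM.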

Compound 4, half-maximal inhibitory concentration: 182000 nM
The estimate for compound 4 lay 1.2-fold (0.08 log units) below the measured number; measured number inside the range.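

In this assay, chloro in place of hydrogen on an aromatic carbon, two atoms from the ring nitrogen, gives a 1.1-fold lower number from compound 2 to compound 4 (0.04 log units; within the scatter). Among these compounds, this is the first pair that differs in one place, and it gives the first direct reading of this position: the step lies within the scatter, so this single chlorine does not separate the two compounds in this assay. Compound 1 and compound 3 offer no further number to set beside this pair: the limit of > 1000000 nM in this assay, at which 2 of the 4 values shown sit.

A single pair cannot show whether this position stays as flat for other groups, such as a nitrile, a methoxy group or a carboxylic acid. It also leaves open whether chloro on the other aromatic carbons of this ring would give the same reading.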